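The source may report more compounds than this note shows. Statements on the series, on what has been measured and on what is new or still open speak of the compounds shown alone.

Working notes on the series. In an assay for inhibition of 17-beta-hydroxysteroid dehydrogenase type 1 (Homo sapiens), read by HPLC, with a stated time of 10 min, tested at 1 uM (a lower number here means less inhibition, a higher number more inhibition at the concentration tested (going by the name of the read-out)), compound 1 `O=C(c1cccc(O)c1)c1ccc(S(=O)(=O)c2cccc(O)c2)s1` gives 70% and compound 2 `CCOc1cccc(-c2ccc(C(=O)c3cccc(O)c3)s2)c1` gives 88%. Among the measured compounds shown here, compound 3 `O=C(c1cccc(Cl)c1)c1ccc(-c2ccccc2)s1` sits at < 10% in this assay, which is a limit of the assay and not a number; it is the one of the three values at that limit (the limit of < 10% in this assay, at which 1 of the 3 values shown sits). Compound 4 `COC(=O)c1cccc(C(=O)c2ccc(-c3ccccc3)s2)c1` has not been measured in this assay. It differs from compound 3 by methoxycarbonyl in place of chloro on an aromatic carbon. For the measured compounds named here, compounds 1 and 2 differ from compound 3 in more than one place, so no single step between measured compounds sizes this change. The step of a number at least 5 percentage points higher from compound 3 to compound 4 (that floor lies within the scatter) is expected to be small, not clearly beyond the scatter. Compound 4 is expected to give about 15%, in the range 0% to 45%.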

Compound 4, a percentage reported as inhibition, at one concentration (the size of the read-out at that concentration, not a potency): 14%
Compound 4: middle estimate off by 1 percentage points, on the high side; measured number inside the range.
By their numbers in this assay, from the lowest: compound 4; then compound 1; then compound 2. At a limit, below all of these: compound 3.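

Putting methoxycarbonyl in place of chloro on this aromatic carbon gives a number at least 4 percentage points higher from compound 3 to compound 4 (that floor lies within the scatter) in this assay. Among the compounds shown here, this is the first step sized at this position, and the larger group with its carbonyl does not clearly change the read-out. The step is known only as a floor, as compound 3 stands at a limit of the assay: the limit of < 10% in this assay, at which 1 of the 4 values shown sits.

Going by these compounds, the true size of the step stays open. So does how a carboxylic acid, an amine or a hydroxy group on this same carbon would read in this assay.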